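Tetrazole in place of the acid on a triaryl pyrazole chain

The compounds below may be only part of what the source reports. "The series", "measured", "known", "first", "only" and "open" are said of these compounds alone.

Measured so far:
compound 1, `O=C(O)CCCCCCCCCn1nc(-c2ccccc2)c(-c2ccccc2)c1-c1ccccc1`: 5500 nM
compound 2, `O=C(O)CCCCCCCn1cc(-c2ccccc2)c(-c2ccccc2)n1`: > 85000 nM

Compound 1 carries the shared core with three phenyl groups and a long saturated chain ending in the acid. In a functional assay for inhibition, with Homo sapiens as the target (on this read-out higher numbers stand for weaker inhibition and lower numbers for stronger inhibition), compound 1 gives 5500 nM, the only numerical result among the two compounds shown. Compound 2, with a shorter chain and one phenyl fewer, reaches only a limit of this assay, > 85000 nM, which is the limit of > 85000 nM in this assay, at which 1 of the 2 values shown sits. Among the measured compounds shown here, no pair of measured compounds differs in a single place, so no measured step is available.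

Compound 3, `c1ccc(-c2nn(CCCCCCCCc3nnn[nH]3)c(-c3ccccc3)c2-c2ccccc2)cc1`, differs from compound 1 by 1H-tetrazol-5-yl in place of carboxymethyl on a saturated chain carbon, eight bonds along the chain from an aromatic nitrogen. For the measured compounds named here, with no measured step to lean on, the change from compound 1 to compound 3 is expected to lie within the usual scatter, in either direction; the estimated step is a 1.2-fold lower number from compound 1 to compound 3 (0.09 log units; within the scatter). For compound 3 in this assay the estimate is 4500 nM, expected to fall between 1500 nM and 15000 nM.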

Compound 3, half-maximal inhibitory concentration: 1040 nM
Beside the measured number, compound 3's estimate is 4.3-fold (0.64 log units) above it; the whole stated range lies above it.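

Among the compounds shown here, the exchange of carboxymethyl for 1H-tetrazol-5-yl, on a saturated chain carbon eight bonds along the chain from an aromatic nitrogen, gives a 5.3-fold lower number from compound 1 to compound 3 (0.72 log units; beyond the scatter) in this assay, and this is the first measured step. It shows that the end of this chain does not need the carboxylic acid for inhibition, since the ring that enters gives stronger inhibition than the group that leaves. Nothing among the compounds shown gives a reason for this gain, which rests on a single pair.

As far as these compounds go, whether the same exchange would hold on a shorter or a longer chain stays open. So does how an amine or a primary amide at the chain end would compare with 1H-tetrazol-5-yl on this core.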